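Replacing the 2-methylphenyl group of compound 2

This account rests on a few compounds, and the source may have more. Where it says the series, first, only, none or still open, it means among the compounds named here.

In a functional assay on A549 cells (Homo sapiens) for inhibition, read by MTT assay, with a stated time of 72 h (a higher number here means a weaker inhibitor, a lower number a stronger inhibitor), three compounds with a shared core have been measured, and they differ only in the chain that ends in hydroxycarbamoyl. Compound 1 `COc1cc2c(Oc3ccc(NC(=O)c4nn(-c5ccccc5C)cc(C)c4=O)cc3)ccnc2cc1OCCCC(=O)NO` gives 4460 nM and compound 2 `COc1cc2c(Oc3ccc(NC(=O)c4nn(-c5ccccc5C)cc(C)c4=O)cc3)ccnc2cc1OCC(=O)NO` gives 5980 nM while compound 3 `COc1cc2c(Oc3ccc(NC(=O)c4nn(-c5ccccc5C)cc(C)c4=O)cc3)ccnc2cc1OCCCCCCC(=O)NO` gives 3130 nM in this test. These numbers sit close together: a 1.3-fold higher number from compound 1 to compound 2 (0.13 log units; within the scatter) and a 1.9-fold lower number from compound 2 to compound 3 (0.28 log units; within the scatter) are both small enough to be within the scatter. On these numbers compound 2 therefore stands level with the other two and is not separated from either.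

Compound 4 `COc1cc2c(Oc3ccc(NC(=O)c4nn(-c5ccc(Cl)c(C(F)(F)F)c5)cc(C)c4=O)cc3)ccnc2cc1OCC(=O)NO` keeps the chain of compound 2 but changes the group on an aromatic nitrogen, where 4-chloro-3-(trifluoromethyl)phenyl comes in place of 2-methylphenyl 4-chloro-3-(trifluoromethyl)phenyl in place of 2-methylphenyl on an aromatic nitrogen in the structure. For the measured compounds named here, none of the measured steps touches this group. All of them alter the chain, so they offer no direct guide to this change, and nothing in the data points firmly in either direction. In this assay no step beyond the scatter is therefore expected, and the range must stay wide. The expected step is a 1.3-fold lower number from compound 2 to compound 4 (0.12 log units; within the scatter) on this reasoning. The estimate for compound 4 is 4500 nM within an expected range of 1800 nM to 12000 nM in this test.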

Compound 4, half-maximal inhibitory concentration: 1590 nM
Estimate against measurement, compound 4: 2.8-fold (0.45 log units) above; the whole stated range lies above it.
By their numbers in this assay, from the lowest: compounds 4, 3, 1 and 2 (each within the scatter of the next, the first and the last beyond it).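

In this assay, putting 4-chloro-3-(trifluoromethyl)phenyl in place of 2-methylphenyl on the aromatic nitrogen gives a clear shift (a 3.8-fold lower number from compound 2 to compound 4 (0.58 log units; beyond the scatter)), though a modest one, while the chain stays exactly as in compound 2. For the compounds shown here, the chain changes among the earlier compounds, even the one from the shortest chain to the longest (a 1.9-fold lower number from compound 2 to compound 3 (0.28 log units; within the scatter)), all stayed within the scatter, so this is the first position where a single change moves the number beyond it. The data at hand offer no measurement that explains the shift.

The new group differs from the old one in both its chlorine and its trifluoromethyl, so the compounds shown cannot say whether one of these alone carries the shift, and a simple 4-chlorophenyl or 3-(trifluoromethyl)phenyl on the same nitrogen, or an unsubstituted phenyl, would be needed to separate them. On these data alone, it also remains open whether 4-chloro-3-(trifluoromethyl)phenyl would give a similar step when paired with the longer chains of compound 1 and compound 3.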